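From cyclopropyl(methyl)amino to 4,4-difluoropiperidin-1-yl: an expected clearance

This account rests on a few compounds, and the source may have more. Where it says the series, first, only, none or still open, it means among the compounds named here.

Compound 1 `CN(C)c1cc(OCc2cc(F)c(Oc3ccc(Cl)c(C(F)(F)F)c3)c(F)c2)nc(=O)n1C`: 82.8 mL/min/kg
Compound 2 `CN(c1cc(OCc2cc(F)c(Oc3ccc(Cl)c(C(F)(F)F)c3)c(F)c2)nc(=O)n1C)C1CC1`: 123 mL/min/kg

Within the data shown here, both values come from an ADME assay on S9 fraction from liver (Rattus norvegicus, strain Wistar) for metabolic stability, tested at 0.1 uM (on this read-out higher numbers stand for fast clearance and lower numbers for slow clearance), and compound 2 stands within the scatter of compound 1, its only measured neighbour. Compound 3 `Cn1c(N2CCC(F)(F)CC2)cc(OCc2cc(F)c(Oc3ccc(Cl)c(C(F)(F)F)c3)c(F)c2)nc1=O` carries 4,4-difluoropiperidin-1-yl in place of cyclopropyl(methyl)amino on an aromatic carbon. Among the measured compounds shown here, the one measured step bearing on this, cyclopropyl in place of methyl on a nitrogen, is a 1.5-fold higher number from compound 1 to compound 2 (0.17 log units; within the scatter) and stayed within the scatter. For the measured compounds named here, no measured step covers a ring of this size, so no change beyond the scatter is expected. The estimated step is a 1.2-fold lower number from compound 2 to compound 3 (0.09 log units; within the scatter) in size. Compound 3 is expected at 100 mL/min/kg within an estimated range from 55 mL/min/kg to 175 mL/min/kg on this read-out.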

Compound 3, clearance: 23.6 mL/min/kg
Compound 3: middle estimate off by 4.2-fold (0.63 log units), on the high side, outside the stated range (below it).
By their numbers in this assay, from the lowest: compound 3; then compounds 1 and 2 (each within the scatter of the next).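

In this assay, the group on this aromatic carbon moves the number beyond the scatter, which the exchange of methyl for cyclopropyl on the nitrogen did not do. Here 4,4-difluoropiperidin-1-yl gives a 5.2-fold lower number from compound 2 to compound 3 (0.72 log units; beyond the scatter) and, set against dimethylamino, a 3.5-fold lower number from compound 1 to compound 3 (0.55 log units; beyond the scatter), so compound 3 stands apart from both open-chain amines. No evidence on the cause of this drop is at hand. Still open, on these data alone, is whether the six-membered ring or its two fluorine atoms account for the step, a question on which unsubstituted piperidin-1-yl or morpholin-4-yl in the same place would bear.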